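A few compounds are considered here, and "the series" means these few. Any claim that something is new, unique, unknown or untested is made for them only; others in the source may bear on it.

Compound 1 `Cc1cc(C)cc(NC(=O)CN2CCC(c3cccc[n+]3[O-])CC2)c1` carries a 3,5-dimethylphenyl group on an amide-type nitrogen. In a functional assay on HEK293 cells for agonist activity at D(4) dopamine receptor (Homo sapiens), read by FLIPR (a lower number here means a smaller maximal response, a higher number a larger maximal response), compound 1 gives 76%, the highest of the three numbers measured here. The nearest of the others is compound 3 `O=C(NCN1CCC(c2cccc[n+]2[O-])CC1)c1cnccc1Cl`, which in this assay gives 44%, a gap to compound 1 beyond the usual scatter. Furthest away is compound 2 `Cc1cccc(NC(=O)CN2CCC(c3cccc(C#N)n3)CC2)c1`, which in this assay gives 42%, also beyond the scatter from compound 1. Compound 4 `O=C(CN1CCC(c2cccc[n+]2[O-])CC1)Nc1ccc(F)cc1` keeps the core of compound 1 and changes only the group on the amide-type nitrogen: 4-fluorophenyl in place of 3,5-dimethylphenyl on an amide-type nitrogen. Within the data shown here, no pair of measured compounds differs in this one place alone, so nothing measured here shows directly what the change does. Given that compound 1 sits highest, the step is expected to go downward, modestly, with a drop near the edge of the scatter judged most likely. For compound 4 a response of 62% is expected, within a range from 38% to 86%. That estimate corresponds to an expected step of a number 14 percentage points lower from compound 1 to compound 4 (beyond the scatter).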

Compound 4, largest response reached (reported as efficacy), in percent of the reference or control that the assay uses: 71%
The estimate for compound 4 lay 9 percentage points below the measured number; the range from low to high includes it.
By their numbers in this assay, from the lowest: compounds 2 and 3 (each within the scatter of the next); then compounds 4 and 1 (each within the scatter of the next).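

Among these compounds, this pair gives the first direct reading at this position, since compounds 1 and 4 differ only in the group on the amide-type nitrogen. In this assay, exchanging 3,5-dimethylphenyl for 4-fluorophenyl gives a step of a number 5 percentage points lower from compound 1 to compound 4 (within the scatter), so this exchange does not separate the two compounds in maximal response. With the shared core unchanged, a ring carrying two methyl groups and one carrying a single fluorine therefore read alike at this position, and nothing available explains this result.

One pair cannot show how far this tolerance extends, such as whether an unsubstituted phenyl, a cyclohexyl ring or a simple ethyl chain on the same nitrogen would keep the response. It also leaves open whether a carboxylic acid or an amine on the phenyl ring would do so.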